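The compounds below may be only part of what the source reports. "The series", "measured", "known", "first", "only" and "open" are said of these compounds alone.

Of the compounds shown here, two have so far been measured in a functional assay on HEK293T cells for agonist activity at histamine H2 receptor (Homo sapiens), read by beta-arrestin recruitment; a higher number here means that more compound is needed for the effect, a lower number that less compound is needed. Compound 1 `Cc1nc(N)sc1CCCN/C(N)=N/C(=O)N[C@H](C)c1ccccc1` gives 45.7 nM in this assay, the lower of the two numbers recorded. Compound 2 `N/C(=N\C(=O)NCc1ccccc1)NC1CCc2nc(N)sc2C1` gives 4370 nM in this assay, and the gap between these two values lies beyond the scatter of repeated measurements. Compound 3 `CCCCCCNC(=O)/N=C(\N)NCCCc1sc(N)nc1C` has not yet been measured; it differs from compound 1 in one place, with hexyl in place of 1-phenylethyl on an amide-type nitrogen. Among the compounds with values here, no pair of measured compounds shows what this exchange does in this assay, so the expectation rests on compound 1 alone, whose 45.7 nM is the starting point. The step of a 3.3-fold higher number from compound 1 to compound 3 (0.52 log units; beyond the scatter) is expected to be modest and to lead towards a higher number, although it could also remain within the scatter. Compound 3 is therefore estimated at 150 nM, with a range from 30 nM to 800 nM.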

Compound 3, half-maximal effective concentration: 85.1 nM
Compound 3: the middle estimate sits 1.8-fold (0.25 log units) above what was measured; the measured number falls inside the stated range.
By their numbers in this assay, from the lowest: compounds 1 and 3 (each within the scatter of the next); then compound 2.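

In this assay, hexyl in place of 1-phenylethyl on the amide-type nitrogen gives a step (a 1.9-fold higher number from compound 1 to compound 3 (0.27 log units; within the scatter)) too small to separate the two compounds. On the core of compound 1, then, this position can hold an open carbon chain with no ring and no defined stereocentre, and the number stays level with that of the 1-phenylethyl compound, so neither the six-membered aromatic ring nor the stereocentre is needed here to keep it there. No measurement is at hand that would explain this result.

As far as these compounds go, whether a shorter chain such as butyl, a longer chain such as octyl, or a hexyl chain ending in an amine or a carboxylic acid would stay level with compound 1 remains open, as does the mirror-image form of 1-phenylethyl. From the compounds shown here alone, this single pair speaks only for the core of compound 1, and what the same exchange would do on the core of compound 2 is also open.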